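The source may report more compounds than this note shows. Statements on the series, on what has been measured and on what is new or still open speak of the compounds shown alone.

In a functional assay on HFF cells (Homo sapiens) for cytotoxicity, read by neutral red uptake (a lower number here means that less compound is tolerated, a higher number that more compound is tolerated), compound 2 `COC(OC)c1cn(C2C[C@H](O)[C@@H](CO)O2)c(=O)[nH]c1=O` gives > 300000 nM, which is a limit of the assay and not a number. Compound 1 `CC(=O)OC[C@H]1OC(n2cc(C=O)c(=O)[nH]c2=O)C[C@@H]1OC(C)=O` gives > 300000 nM, also a limit. The whole measured set reads the same way: the limit of > 300000 nM in this assay, at which 3 of the 3 values shown sit. Compound 4 `O=c1[nH]c(=O)n(C2C[C@H](O)[C@@H](CO)O2)cc1C1OCCCO1` has not yet been measured. Its difference from compound 2 is a group of 6 heavy atoms (4 carbon, 2 oxygen; one six-membered non-aromatic ring with 2 hetero atoms) in place of a group of 5 heavy atoms (3 carbon, 2 oxygen; no ring), on an aromatic carbon, so a ring-bearing group replaces dimethoxymethyl on an aromatic carbon. The closest measured change is a step that the two limits leave unreadable from compound 1 to compound 3, where 1,3-dioxolan-2-yl replaces formyl, and it yields no size. Compound 3 `CC(=O)OC[C@H]1OC(n2cc(C3OCCO3)c(=O)[nH]c2=O)C[C@@H]1OC(C)=O`, which carries that ring-bearing group, gives > 300000 nM, again a limit, so a similar reading is expected for compound 4. For the measured compounds named here, no measured step points to a shift beyond the usual scatter in this assay, in either direction. The expected change is a number no higher from compound 2 to compound 4 (the limit leaves the size open), and it is most likely to appear only as another limit. For compound 4 the estimated value is 300000 nM, with an expected range of 150000 nM to 600000 nM.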

Compound 4, half-maximal cytotoxic concentration: > 300000 nM
Compound 4: no number, only a limit; the forecaster's own chance of this, stated with the estimate: 85%; the middle value lies on the limit itself.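

No new step can be read, as compound 2 and compound 4 both give only a limit in this assay: the limit of > 300000 nM in this assay, at which 4 of the 4 values shown sit. The compounds shown leave open whether any of them has a numerical value in this assay and whether exchanging these groups changes it.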